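This account rests on a few compounds, and the source may have more. Where it says the series, first, only, none or still open, it means among the compounds named here.

Three close relatives have so far been tested in a functional assay on QG-56 cells (Homo sapiens) for cytotoxicity, read by MTT assay, with a stated time of 48 h; a lower number here means a stronger inhibitor, a higher number a weaker inhibitor. There compound 1 (`COc1cc(/C=C/C(=O)C2=C(/C=C/c3ccc(O)c(OC)c3)NC(=O)NC2c2ccccc2O)ccc1O`) gives 100000 nM while compound 2 (`COc1cc(/C=C/C(=O)C2=C(/C=C/c3ccc(O)c(OC)c3)NC(=O)NC2c2cccc([N+](=O)[O-])c2)ccc1O`) gives 25000 nM and compound 3 (`COc1cc(/C=C/C(=O)C2=C(/C=C/c3ccc(O)c(OC)c3)NC(=S)NC2c2ccccc2O)ccc1O`) gives 50000 nM as its result. The value of compound 3 lies within the usual scatter of each of the other two, so it cannot be told apart from either.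

Compound 4 (`COc1cc(/C=C/C(=O)C2=C(/C=C/c3ccc(O)c(OC)c3)NC(=S)NC2c2ccccc2Cl)ccc1O`) keeps all of compound 3 except one group (chloro in place of hydroxy on an aromatic carbon): chloro in place of hydroxy on an aromatic carbon, ortho to a large group, which turns 2-hydroxyphenyl into 2-chlorophenyl.

Within the data shown here, no measured pair shows this exact swap. The closest evidence is a single step that also removes 2-hydroxyphenyl, with 3-nitrophenyl entering on a saturated ring carbon: a 4.0-fold lower number from compound 1 to compound 2 (0.60 log units; beyond the scatter) in a modest move beyond the scatter. Since the incoming group differs, only part of that move is carried over here. Going by that one step, the expected change is a modest one towards a lower number, with a 2.3-fold lower number from compound 3 to compound 4 (0.36 log units; beyond the scatter) as the estimated step in this assay and a wide margin around it. Compound 4 is estimated at 22000 nM and expected to fall between 9000 nM and 60000 nM.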

Compound 4, half-maximal inhibitory concentration: 50000 nM
Estimate against measurement, compound 4: 2.3-fold (0.36 log units) below; measured number inside the range.
By their numbers in this assay, from the lowest: compounds 2, 3, 4 and 1 (each within the scatter of the next, the first and the last beyond it).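

In this assay, chloro in place of hydroxy on an aromatic carbon, ortho to a large group, gives no change at the digits printed from compound 3 to compound 4 (within the scatter). The hydroxy counts as one hydrogen-bond donor and one hydrogen-bond acceptor and the chloro as neither, yet this exchange leaves no difference that this assay can read between these two compounds. Taking away the hydroxy of the 2-hydroxyphenyl group is therefore not enough, in this pair, to reproduce the earlier step of a 4.0-fold lower number from compound 1 to compound 2 (0.60 log units; beyond the scatter), although that step brought in a different group and was measured on compounds with oxygen rather than sulfur on the shared core, and no measurement here explains why hydroxy and chloro read alike.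

On these data alone, whether an amino group or a methyl group at this same place would also match the hydroxy and the chloro remains open. As far as these compounds go, it is equally open whether 2-chlorophenyl would read the same on the oxygen-bearing core of compound 1, or whether the 3-nitrophenyl group of compound 2 would keep its lower number on the sulfur-bearing core.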